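From Imidazole to Triazole on the Shared Urea Core

The source may hold more compounds than are shown below. What is called first, only, known or untested is meant among the compounds shown, and "the series" means these compounds.

Measured so far in an assay on microsomes from intestine for inhibition of acyl-CoA:cholesterol acyltransferase (Oryctolagus cuniculus); on this read-out lower numbers stand for stronger inhibition and higher numbers for weaker inhibition:
Compound 1 `Cc1cc(C)c(NC(=O)N(Cc2ccc(-c3ccsc3)cc2)C2CCCCCC2)c(C)c1`: 19 nM
Compound 2 `Cc1cc(C)c(NC(=O)N(Cc2ccc(-n3ccnc3)cc2)C2CCCCCC2)c(C)c1`: 47 nM

Compound 2 stands highest of the two numbers in this assay. Among the measured compounds shown here, the only measured step, a 2.5-fold higher number from compound 1 to compound 2 (0.39 log units; beyond the scatter), is modest and beyond the scatter, and it exchanged one ring for another at the same aromatic carbon.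

Compound 3 `Cc1cc(C)c(NC(=O)N(Cc2ccc(-n3cncn3)cc2)C2CCCCCC2)c(C)c1` is the next change: 1H-1,2,4-triazol-1-yl in place of 1H-imidazol-1-yl on an aromatic carbon. For the measured compounds named here, no measured step covers this exchange; the step from compound 1 to compound 2 only shows that swapping a five-membered ring at this carbon moves this assay modestly. A small shift, at most slightly beyond the scatter and toward a higher number, is expected. Compound 3 is therefore estimated at 60 nM, between 20 nM and 180 nM, which is expected to mean a 1.3-fold higher number from compound 2 to compound 3 (0.11 log units; within the scatter).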

Compound 3, half-maximal inhibitory concentration: 26 nM
Estimate against measurement, compound 3: 2.3-fold (0.36 log units) above, and the stated range covers the measured number.
By their numbers in this assay, from the lowest: compounds 1, 3 and 2 (each within the scatter of the next, the first and the last beyond it).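

With 1H-1,2,4-triazol-1-yl in place of 1H-imidazol-1-yl, this assay shows a 1.8-fold lower number from compound 2 to compound 3 (0.26 log units; within the scatter) and, with the same ring in place of thiophen-3-yl, a 1.4-fold higher number from compound 1 to compound 3 (0.14 log units; within the scatter) at this aromatic carbon. A third five-membered aromatic ring therefore sits within the scatter of both earlier compounds, although compound 1 and compound 2 lie beyond the scatter of each other. Nothing available accounts for these numbers. The compounds shown leave open how an amine, a carboxylic acid or a pyridine ring on this carbon would read, and whether these exchanges would give similar steps on another core.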